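The compounds below may be only part of what the source reports. "The series", "measured", "known", "first", "only" and "open" are said of these compounds alone.

Compound 1, `O=C(O)c1ccc(-c2cnc(C(=O)CCc3ccc(-c4ccccc4)cc3)o2)cn1`, gives 44 nM in an assay for inhibition of Fatty-acid amide hydrolase 1 (Rattus norvegicus); on this read-out lower numbers stand for stronger inhibition and higher numbers for weaker inhibition. Compound 2, `O=C(O)c1cccc(-c2cnc(C(=O)CCc3ccc(-c4ccc(CN5CCCCC5)cc4)cc3)o2)n1`, gives 44 nM. Compound 3, `COC(=O)c1cccc(-c2cnc(C(=O)CCc3ccc(-c4ccc(CN5CCCCC5)cc4)cc3)o2)n1`, gives 9 nM.

Among these three numbers compound 1 stands level with compound 2, and together they are the highest of the set; compound 3 is the only one lower, and by a margin beyond the scatter.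

Compound 4, `COC(=O)c1ccc(-c2cnc(C(=O)CCc3ccc(-c4ccccc4)cc3)o2)cn1`, differs from compound 1 by methyl in place of hydrogen on an oxygen next to a carbonyl group. Within the data shown here, one measured step bears directly on this change: a 4.9-fold lower number from compound 2 to compound 3 (0.69 log units; beyond the scatter), the same exchange made on a closely related pair. On that basis a step of similar size and in the same direction is expected in this assay, that is a lower number for compound 4. Compound 4 is therefore estimated at 9 nM, with a range from 4 nM to 25 nM, which would be an expected 4.9-fold lower number from compound 1 to compound 4 (0.69 log units; beyond the scatter).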

Compound 4, inhibition constant: 0.6 nM
For compound 4 the middle estimate is 15-fold (1.18 log units) above the measured one; the whole stated range lies above it.
By their numbers in this assay, from the lowest: compound 4; then compound 3; then compounds 1 and 2 (each within the scatter of the next).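

Exchanging carboxy for methoxycarbonyl gives a 73-fold lower number from compound 1 to compound 4 (1.87 log units; beyond the scatter), a far larger step than the earlier pair showed. The direction of the change therefore held on both cores in this assay, but its size did not carry over from one core to the other: the same change on two cores in this assay, a 4.9-fold lower number (0.69 log units; beyond the scatter) from compound 2 to compound 3 and a 73-fold lower number (1.87 log units; beyond the scatter) from compound 1 to compound 4, 15-fold (1.18 log units) apart, beyond the scatter of two such steps

The two cores differ in more than one place, so the compounds shown cannot tell which of those differences sets the size of the step. From the compounds shown here alone, it also remains open whether an ethyl ester or a primary amide in place of methoxycarbonyl would keep the low number of compound 4.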